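The compounds below may be only part of what the source reports. "The series", "measured", "known", "first", "only" and "open" are said of these compounds alone.

Measured in a functional assay on HL-60 cells (Homo sapiens) for inhibition, read by MTT assay; a higher number here means a weaker inhibitor, a lower number a stronger inhibitor:
- compound 1 `O=C(/C=C/c1cc(O)c(O)c([N+](=O)[O-])c1)OCCc1ccccc1`: "not determined" (no result reported)
- compound 2 `O=C(/C=C/c1ccc(O)c(O)c1[N+](=O)[O-])OCCc1ccccc1`: 18200 nM
- compound 3 `CC1(C)C2CCC1(C)C(OC(=O)/C=C/c1ccc(O)c(O)c1)C2`: 3350 nM

Compound 1 has no place on this scale, since no result was reported for it. Any comparison with it therefore remains open. The two numbers that do exist are far enough apart to matter: compound 3 gives 3350 nM, a lower number and so a stronger inhibitor than compound 2 at 18200 nM.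

The next molecule is compound 4 `O=C(/C=C/c1cc(O)c(O)c(Cl)c1)OCCc1ccccc1`, which has chloro in place of nitro on an aromatic carbon of the core of compound 1: chloro in place of nitro on an aromatic carbon. The new chloro group sits ortho to a hydroxy group.

With no starting number, the size of this step in this assay can only be expected, not calculated. If compound 1 lay close to compound 2, a moderate step toward stronger inhibition would be expected, landing within the span set by compound 2 and compound 3. For compound 4 the estimated value is 8000 nM, with an expected range from 2500 nM to 25000 nM.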

Compound 4, half-maximal inhibitory concentration: 7010 nM
The estimate for compound 4 lay 1.1-fold (0.06 log units) above the measured number; measured number inside the range.
By their numbers in this assay, from the lowest: compound 3; then compound 4; then compound 2.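

Compound 1 has no number in this assay, so the change from nitro to chloro that leads to compound 4 cannot be read as a step. From the compounds shown here alone, whether chloro strengthens or weakens inhibition relative to nitro at this place stays open. Nothing measured here explains the value of compound 4.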